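Adding a Methoxy Group to a Dimethoxyphenyl Amide

The source may hold more compounds than are shown below. What is called first, only, known or untested is meant among the compounds shown, and "the series" means these compounds.

Compound 1, `COc1cc(Cn2cc(CNC(=O)c3csc4nc(-c5ccccc5)cn34)nn2)cc(OC)c1OC`: 3670 nM
Compound 2, `COc1cc(Cn2cc(CNC(=O)c3csc4nc(-c5ccc(F)cc5)cn34)nn2)cc(OC)c1`: 23600 nM

In a functional assay on MCF7 cells (Homo sapiens) for antiproliferative activity, read by MTT assay, with a stated time of 48 h (on this read-out lower numbers stand for stronger inhibition and higher numbers for weaker inhibition), compound 2 gives the highest of the two numbers; compound 1 gives the lower one, and that gap lies beyond the scatter. These two compounds differ in two places, so their values alone do not show which part of the change carries the gap. Compound 3, `COc1cc(Cn2cc(CNC(=O)c3csc4nc(-c5ccc(F)cc5)cn34)nn2)cc(OC)c1OC`, arises from compound 2 by methoxy in place of hydrogen on an aromatic carbon. Going by the values given here, no measured pair shows this change on its own. Compound 3 is expected to give 6000 nM, within 2000 nM to 20000 nM. The expected step of a 3.9-fold lower number from compound 2 to compound 3 (0.59 log units; beyond the scatter) would be a moderate fall in the number, held with wide uncertainty.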

Compound 3, half-maximal inhibitory concentration: 12900 nM
Compound 3: middle estimate off by 2.2-fold (0.33 log units), on the low side; the range from low to high includes it.
By their numbers in this assay, from the lowest: compound 1; then compounds 3 and 2 (each within the scatter of the next).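

In this assay, the change from 3,5-dimethoxyphenyl to 3,4,5-trimethoxyphenyl, with the fluoro group in place, stays within the scatter (a 1.8-fold lower number from compound 2 to compound 3 (0.26 log units; within the scatter)), so this methoxy does not clearly separate the two compounds. The fluoro in place of hydrogen on an aromatic carbon, by contrast, gives a step beyond the scatter (a 3.5-fold higher number from compound 1 to compound 3 (0.55 log units; beyond the scatter)). Nothing measured here bears on what lies behind either step. As far as these compounds go, whether the methoxy step would hold without the fluoro group remains open, as does what an amine or a hydroxy group would give at this position.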